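Growing the group on the ring oxygen: compound 4

A few compounds are considered here, and "the series" means these few. Any claim that something is new, unique, unknown or untested is made for them only; others in the source may bear on it.

Measured so far:
compound 1 `COc1cc(-c2cnn3cc(OC)c(-c4cnn(C)c4)nc23)ccn1`: 530 nM
compound 2 `COc1cn2ncc(-c3ccnc(OC(C)C)c3)c2nc1-c1cnn(C)c1`: 2300 nM
compound 3 `COc1cn2ncc(-c3ccnc(OC4CC4)c3)c2nc1-c1cnn(C)c1`: 860 nM

In an assay on isolated protein for inhibition of activin receptor type-2A (Homo sapiens), read by 33P incorporation, with a stated time of 20 min, in the presence of a further agent that is not named here (on this read-out higher numbers stand for weaker inhibition and lower numbers for stronger inhibition), compound 3 gives 860 nM, the second highest of the three numbers; it sits within the scatter of compound 1 (a 1.6-fold higher number from compound 1 to compound 3 (0.21 log units; within the scatter)) and beyond it from compound 2 (a 2.7-fold lower number from compound 2 to compound 3 (0.43 log units; beyond the scatter)). Compound 4 `COc1cn2ncc(-c3ccnc(OC(C)(C)C)c3)c2nc1-c1cnn(C)c1` differs from compound 3 by tert-butyl in place of cyclopropyl on an oxygen on an aromatic ring. For the measured compounds named here, the steps that bear on this change are the earlier enlargements at the same oxygen, a 4.3-fold higher number from compound 1 to compound 2 (0.64 log units; beyond the scatter) and a 2.7-fold lower number from compound 2 to compound 3 (0.43 log units; beyond the scatter). Across compounds 1, 2 and 3 the branched acyclic group carries the highest number, so a still larger acyclic group is expected to raise the number beyond the scatter, a 4.7-fold higher number from compound 3 to compound 4 (0.67 log units; beyond the scatter). Compound 4 is therefore estimated at 4000 nM, with a range of 1500 nM to 12000 nM.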

Compound 4, half-maximal inhibitory concentration: 800 nM
Estimate against measurement, compound 4: 5.0-fold (0.70 log units) above; the whole stated range lies above it.
By their numbers in this assay, from the lowest: compounds 1, 4 and 3 (each within the scatter of the next); then compound 2.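

In this assay tert-butyl on the oxygen reads level with cyclopropyl (a 1.1-fold lower number from compound 3 to compound 4 (0.03 log units; within the scatter)) and with methyl (a 1.5-fold higher number from compound 1 to compound 4 (0.18 log units; within the scatter)), whereas adding a methyl to isopropyl gives a 2.9-fold lower number from compound 2 to compound 4 (0.46 log units; beyond the scatter). The number therefore does not follow group size at this oxygen: compound 2 stands apart from both the smaller compound 1 and the larger compound 4. No available evidence bears on this result.

Still open, from the compounds shown here alone, is how an amine or a longer chain on this oxygen would read, and whether any group there can give a number beyond the scatter below compound 1.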